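This account rests on a few compounds, and the source may have more. Where it says the series, first, only, none or still open, it means among the compounds named here.

Measured in an ADME assay on microsomes from liver (Homo sapiens) for metabolic stability, read by LC-MS, using NADPH, with stated times of 5 min and 30 min, tested at 1 uM; on this read-out higher numbers stand for fast clearance and lower numbers for slow clearance:
- compound 1 `Cc1ncccc1-c1cnc(NCc2c(F)ccc3c2CCO3)c2nn(CC#N)c(=O)n12`: 151 mL.min-1.g-1
- compound 2 `Cc1nccn1-c1cnc(NCc2c(F)ccc3c2CCO3)c2cn[nH]c(=O)c12`: 8 mL.min-1.g-1
- compound 3 `O=C1CCCN1c1cnc(NCc2c(F)ccc3c2CCO3)c2cn[nH]c(=O)c12`: 23 mL.min-1.g-1

Of these three, compound 3 holds the middle place, above compound 2 and below compound 1. Compound 4 `Cc1nc(CN(C)C)ccc1-c1cnc(NCc2c(F)ccc3c2CCO3)c2cn[nH]c(=O)c12` has 6-((dimethylamino)methyl)-2-methylpyridin-3-yl in place of 2-oxopyrrolidin-1-yl on an aromatic carbon. Going by the values given here, only one measured step changes this same place, a 2.9-fold higher number from compound 2 to compound 3 (0.46 log units; beyond the scatter). It shows that the group here can shift the number modestly, but it gives no direction for the new group. The core of compound 1 differs, so it offers little guidance. The expected change is therefore small, and the estimated step is a 1.3-fold higher number from compound 3 to compound 4 (0.12 log units; within the scatter). For compound 4 the estimate is 30 mL.min-1.g-1, with an expected range of 10 mL.min-1.g-1 to 90 mL.min-1.g-1.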

Compound 4, intrinsic clearance in microsomes: 13 mL.min-1.g-1
Compound 4: the middle estimate sits 2.3-fold (0.36 log units) above what was measured; measured number inside the range.
By their numbers in this assay, from the lowest: compounds 2, 4 and 3 (each within the scatter of the next, the first and the last beyond it); then compound 1.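

In this assay, the larger 6-((dimethylamino)methyl)-2-methylpyridin-3-yl group gives no clear shift at this position on the shared core: the change shows a 1.8-fold lower number from compound 3 to compound 4 (0.25 log units; within the scatter) and, against the 2-methyl-1H-imidazol-1-yl group, a 1.6-fold higher number from compound 2 to compound 4 (0.21 log units; within the scatter). A group carrying a dimethylaminomethyl chain therefore sits within the scatter of both earlier groups, even though those two differ beyond it. No measurement here explains this result. Still open, on these data alone, is whether the pyridine ring or its chain sets the number; comparing a plain 2-methylpyridin-3-yl group, or a carboxylic acid in place of the amine, would separate the two.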